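The source may hold more compounds than are shown below. What is called first, only, known or untested is meant among the compounds shown, and "the series" means these compounds.

Compound 1: `C=CC1=C(C(=O)NCc2ccccc2)C(c2ccc(OC)c(OC)c2)OC1`, in a functional assay on HeLa cells (Homo sapiens) for cytotoxicity, read by MTT assay, with a stated time of 24 h; on this read-out lower numbers stand for stronger inhibition and higher numbers for weaker inhibition: > 100000 nM
Compound 2: `C=CC1=C(C(=O)NCC(C)C)C(c2ccc(F)cc2)OC1`, in this assay: > 100000 nM
Compound 3: `C=CC1=C(C(=O)NCc2ccc(OC)c(OC)c2)C(c2ccc(F)cc2)OC1`, in this assay: > 100000 nM

Of the compounds shown here, three sharing one core have been tested in this assay, and none gave a number. For compound 1 the entry of > 100000 nM is a limit of the assay, not a measured value. For compound 2 the entry of > 100000 nM is likewise only a limit. For compound 3 the entry of > 100000 nM is again a limit. Compound 2 therefore stands nowhere in particular among the three: all sit together at the limit of > 100000 nM in this assay, at which 3 of the 3 values shown sit, and no order can be read from them.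

The next compound, compound 4 with the structure `C=CC1=C(C(=O)NCc2ccccc2)C(c2ccc(F)cc2)OC1`, has not been measured. It differs from compound 2 in one place: phenyl in place of isopropyl on a saturated chain carbon bound to an amide-type nitrogen. Compound 1 carries the same benzyl amide, though on a different aryl group, and it sits at the limit as well.

Since every shown compound sits at the limit, no step in this assay beyond the scatter is expected from compound 2 to compound 4; the step that the limit leaves unreadable from compound 2 to compound 4 is an estimate only. For compound 4 the expected outcome is another limit, with an estimated value of 200000 nM and a range from 80000 nM to 1000000 nM.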

Compound 4, half-maximal inhibitory concentration: > 100000 nM
Compound 4: a limit, no number; the forecaster's own chance of this, stated with the estimate: 85%; the middle value does not contradict the limit.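

In this assay compound 4 gives > 100000 nM, which is a limit and not a number. Compound 2 is also recorded only as a limit, so no step can be read between compound 2 and compound 4: the limit of > 100000 nM in this assay, at which 4 of the 4 values shown sit.

The compounds shown leave open whether any compound on the shared core reaches a measurable value in this assay.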